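Fluorines on the benzoyl ring of a fused triazole core

A few compounds are considered here, and "the series" means these few. Any claim that something is new, unique, unknown or untested is made for them only; others in the source may bear on it.

The measured compounds in a functional assay on A549 cells (Homo sapiens) for cytotoxicity, read by MTT assay, with a stated time of 48 h; a higher number here means a weaker inhibitor, a lower number a stronger inhibitor:
- compound 1 `COc1cc(-c2nnc3n2NC(c2ccco2)C(C(=O)c2ccccc2C)S3)cc(OC)c1OC` gives 80000 nM
- compound 2 `COc1cc(-c2nnc3n2NC(c2ccco2)C(C(=O)c2ccccc2F)S3)cc(OC)c1OC` gives 78700 nM
- compound 3 `COc1cc(-c2nnc3n2NC(c2ccco2)C(C(=O)c2ccc(F)cc2)S3)cc(OC)c1OC` gives 53700 nM

Compound 1 sits at one end of these three numbers, with compound 2 the nearest (a 1.0-fold lower number from compound 1 to compound 2 (0.01 log units; within the scatter)) and compound 3 the furthest (a 1.5-fold lower number from compound 1 to compound 3 (0.17 log units; within the scatter)); neither gap is beyond the scatter. The step from compound 2 to compound 3 is of the same order (a 1.5-fold lower number from compound 2 to compound 3 (0.17 log units; within the scatter)), so the three benzoyl variants seen so far are not separated by anything the assay can resolve.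

Compound 4 `COc1cc(-c2nnc3n2NC(c2ccco2)C(C(=O)c2ccc(F)c(F)c2)S3)cc(OC)c1OC` is the next variant. Its difference from compound 1: 3,4-difluorophenyl in place of 2-methylphenyl on a carbonyl carbon. Among the measured compounds shown here, the steps that bear on it are those that also exchange the ring on the carbonyl carbon, from compound 1 to compound 2, from compound 1 to compound 3 and from compound 2 to compound 3, and all three were within the scatter. From the compounds shown here alone, a second fluorine on the ring is untested here, so nothing beyond that scatter can be expected. Compound 4 is therefore expected to give 58000 nM, within 28000 nM to 120000 nM, and the expected step from compound 1 is a 1.4-fold lower number from compound 1 to compound 4 (0.14 log units; within the scatter).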

Compound 4, half-maximal inhibitory concentration: 93700 nM
Compound 4: the middle estimate sits 1.6-fold (0.21 log units) below what was measured; the range from low to high includes it.
By their numbers in this assay, from the lowest: compounds 3, 2, 1 and 4 (each within the scatter of the next).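

In this assay, among the compounds shown here, the first compound with two fluorines on the benzoyl ring shows that adding a fluorine to the 4-fluorophenyl group gives no step the assay can resolve (a 1.7-fold higher number from compound 3 to compound 4 (0.24 log units; within the scatter)). The exchanges of the singly substituted rings for 3,4-difluorophenyl on the carbonyl carbon read the same way (a 1.2-fold higher number from compound 1 to compound 4 (0.07 log units; within the scatter); a 1.2-fold higher number from compound 2 to compound 4 (0.08 log units; within the scatter)), so a ring carrying two fluorines now joins those carrying one methyl or one fluorine, and all six steps among the four compounds lie within the scatter. No independent measurement bears on this result, and the numbers alone offer no account of it.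

The compounds shown carry only methyl or fluoro on this ring, so it remains open whether a ring bearing an amine, a carboxylic acid or a methoxy group, or a longer chain in place of the ring on the carbonyl carbon, would give a step beyond the scatter. From the compounds shown here alone, it also remains open whether any of these four benzoyl variants would read differently if the shared core were changed elsewhere.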